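A few compounds are considered here, and "the series" means these few. Any claim that something is new, unique, unknown or untested is made for them only; others in the source may bear on it.

Measured so far in an assay on isolated protein for binding affinity to corticotropin-releasing factor receptor 1 (Homo sapiens); a higher number here means a weaker inhibitor, a lower number a stronger inhibitor:
compound 1, `C=CCN(CC=C)c1nc(C)nc(Nc2c(C)cc(C)cc2C)n1`: 115 nM
compound 2, `C=CCN(CC=C)c1nc(C)nc(Nc2c(C)cccc2C)n1`: its value is a limit of the assay, > 10000 nM
compound 3, `CCN(Cc1ccccc1)c1nc(C)nc(Nc2c(C)cccc2C)n1`: its value is likewise a limit of the assay, > 10000 nM

The change methyl in place of hydrogen on an aromatic carbon gives an at least 86-fold lower number from compound 2 to compound 1 (1.93 log units; beyond the scatter); the size of that step rests on (the limit of > 10000 nM in this assay, at which 2 of the 3 values shown sit), at which compound 2 sits, so its true size is not known. How the core of compound 3 differs from that of compound 2 is not broken down here. Compound 4, `CCN(Cc1ccccc1)c1nc(C)nc(Nc2c(C)cc(C)cc2C)n1`, carries the same change, (methyl in place of hydrogen on an aromatic carbon), on the core of compound 3. As far as these compounds go, since compound 3 also sits at a limit, the step from compound 3 to compound 4 is expected to be an at least 12-fold lower number from compound 3 to compound 4 (1.09 log units; beyond the scatter) in this assay, with the added uncertainty that the core of compound 3 is untested with this methyl. Compound 4 is estimated at 800 nM, expected between 80 nM and 10000 nM.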

Compound 4, inhibition constant: 1470 nM
Compound 4: the middle estimate sits 1.8-fold (0.26 log units) below what was measured; low and high end bracket the measured number.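

In this assay the change from 2,6-dimethylphenyl to 2,4,6-trimethylphenyl again lowers the number, with an at least 6.8-fold lower number from compound 3 to compound 4 (0.83 log units; beyond the scatter), so on both cores shown the methyl acts in the same direction. This does not show that the size of the step carries over from one core to the other: the same change on two cores in this assay, an at least 86-fold lower number (1.93 log units; beyond the scatter) from compound 2 to compound 1 and an at least 6.8-fold lower number (0.83 log units; beyond the scatter) from compound 3 to compound 4; the limit leaves it open whether they differ. Neither step has a known true size, as each starts from a compound at a limit: the limit of > 10000 nM in this assay, at which 2 of the 4 values shown sit.

Still open, as far as these compounds go, is whether a methoxy group or a chlorine atom in place of that methyl lowers the number as well. Also open, from the compounds shown here alone, is whether the step holds when the amine on the core carries longer chains, such as two propyl groups.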